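Inverting one ring stereocentre of compound 1

This account rests on a few compounds, and the source may have more. Where it says the series, first, only, none or still open, it means among the compounds named here.

In a functional assay on MT4 cells (Homo sapiens) for antiproliferative activity (a lower number here means that less compound is tolerated, a higher number that more compound is tolerated), compound 1 (`Cc1cn(C2OC(CO[Si](C)(C)C(C)(C)C)C3(OS(=O)(=O)C=C3N)C2O[Si](C)(C)C(C)(C)C)c(=O)n(CCCNC(=O)[C@@H]2CCCN2C(=O)[C@@H](N)C(C)C)c1=O`) gives 11000 nM while compound 2 (`Cc1cn(C2OC(CO[Si](C)(C)C(C)(C)C)C3(OS(=O)(=O)C=C3N)C2O[Si](C)(C)C(C)(C)C)c(=O)n(CCCNC(=O)[C@@H]2CCCN2C(=O)[C@@H](N)CC(N)=O)c1=O`) gives 22000 nM and so the two cannot be told apart. Among the measured compounds shown here, their one measured step, a 2.0-fold higher number from compound 1 to compound 2 (0.30 log units; within the scatter), puts carbamoylmethyl in place of isopropyl on a saturated chain carbon bound to an amine nitrogen and a carbonyl carbon. Compound 3 (`Cc1cn(C2OC(CO[Si](C)(C)C(C)(C)C)C3(OS(=O)(=O)C=C3N)C2O[Si](C)(C)C(C)(C)C)c(=O)n(CCCNC(=O)[C@H]2CCCN2C(=O)[C@@H](N)C(C)C)c1=O`) brings a different kind of change (the two compounds have the same atoms and bonds; at least one stereo element is drawn with a configuration in one of them and without one in the other: 1 of 6 stereo elements differ; a stereocentre at a saturated ring carbon is drawn S in compound 1 and R in compound 3): a stereocentre at a saturated ring carbon is drawn S in compound 1 and R in compound 3. For the measured compounds named here, no measured step touches that stereocentre, so the guidance is only indirect. Going by the step of a 2.0-fold higher number from compound 1 to compound 2 (0.30 log units; within the scatter) alone, no shift beyond the scatter is expected in this assay for this change. The estimated step is a 1.3-fold higher number from compound 1 to compound 3 (0.10 log units; within the scatter) and it remains an expectation. Compound 3 is expected at 14000 nM (estimated range 6500 nM to 30000 nM).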

Compound 3, half-maximal cytotoxic concentration: 22000 nM
The estimate for compound 3 lay 1.6-fold (0.20 log units) below the measured number; the measured number falls inside the stated range.
By their numbers in this assay, from the lowest: compounds 1, 2 and 3 (each within the scatter of the next).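

In this assay, the stereocentre at a saturated ring carbon can now be read directly, and drawing it R in place of S gives a 2.0-fold higher number from compound 1 to compound 3 (0.30 log units; within the scatter). This single change therefore cannot be told apart from the ordinary spread of repeated measurements. Before this result, the only measured step concerned a different place, the swap of isopropyl for carbamoylmethyl, so nothing yet showed how this stereocentre behaves, and one caution applies to the comparison:  the fact that one of compounds 1 and 3 is drawn with a defined configuration and the other without, at the place where they differ

The compounds shown leave open whether inverting this stereocentre would give the same result in a compound carrying carbamoylmethyl in place of isopropyl. Going by these compounds, it is also open whether a carboxylic acid or a benzyl group on that saturated chain carbon would move the number beyond the scatter.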